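A Methoxy Group on the Aromatic Ring of Compound 1

A few compounds are considered here, and "the series" means these few. Any claim that something is new, unique, unknown or untested is made for them only; others in the source may bear on it.

Compound 1 `C(=C1\CCN=C1c1cccnc1)\c1ccccc1` gives only a limit in an assay for displacement of a labelled ligand from Nicotinic acetylcholine receptor alpha8 subunit (Periplaneta americana), read by scintillation counting, with a stated time of 2 h, at 24 degrees C (a lower number here means a stronger inhibitor, a higher number a weaker inhibitor), reported as > 10000 nM; that is the limit of the assay rather than a number (the limit of > 10000 nM in this assay, at which 1 of the 3 values shown sits). Compound 2 `Oc1ccc(/C=C2\CCN=C2c2cccnc2)cc1` gives 310 nM in this assay, and compound 3 `Oc1ccccc1/C=C1\CCN=C1c1cccnc1` gives 6900 nM. The step of an at least 32-fold lower number from compound 1 to compound 2 (1.50 log units; beyond the scatter) is large, whereas the step of an at least 1.4-fold lower number from compound 1 to compound 3 (0.16 log units; that floor lies within the scatter) is small. Compound 4 `COc1cccc(/C=C2\CCN=C2c2cccnc2)c1` differs from compound 1 by methoxy in place of hydrogen on an aromatic carbon. Both measured steps add a group to the same ring and point the same way with very different sizes, so a lower number than the limit of compound 1 is expected, by an amount between the two. Compound 4 is therefore expected to give 3000 nM (range 800 nM to 12000 nM), a step of an at least 3.3-fold lower number from compound 1 to compound 4 (0.52 log units; beyond the scatter).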

Compound 4, half-maximal inhibitory concentration: > 10000 nM
Compound 4: only a limit was reported; the forecaster's own chance of this, stated with the estimate: 25%; middle value at least 3.3-fold (0.52 log units) from the limit.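

No step from compound 1 to compound 4 can be read, because each gives only a limit: the limit of > 10000 nM in this assay, at which 2 of the 4 values shown sit.

The compounds shown leave open whether methoxy in place of hydrogen changes the number in this assay at all.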